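The source may hold more compounds than are shown below. What is called first, only, known or untested is meant among the compounds shown, and "the series" means these compounds.

Compound 1 (`COc1cc(C2=NN(C(C)=O)C(c3cc(Cl)cc(Cl)c3)O2)cc(OC)c1OC`) was tested in a functional assay on BGC-823 cells (Homo sapiens) for antiproliferative activity, read by MTT assay, tested at 1 uM (on this read-out lower numbers stand for a weaker effect and higher numbers for a stronger effect at the one concentration tested), and gave 0%, the lowest of the three numbers recorded. The two other compounds measured in this assay share only part of its structure: compound 2 (`COc1cc(C(=O)N/N=C/c2cccc(F)c2)cc(OC)c1OC`) gave 13.6%, and compound 3 (`COc1cc(C(=O)N/N=C/c2ccc(C(F)(F)F)cc2)cc(OC)c1OC`) gave 47.4%. Both of those numbers lie beyond the usual scatter above the number of compound 1, with compound 3 the furthest from it. Since compound 2 and compound 3 differ from compound 1 in more than one place, none of these gaps can be tied to a single structural change.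

Compound 4 (`COc1cc(C2=NN(C(C)=O)C(c3ccccc3F)O2)cc(OC)c1OC`) differs from compound 1 in one place only: 2-fluorophenyl in place of 3,5-dichlorophenyl on a saturated ring carbon. For the measured compounds named here, no pair of measured compounds separated by a single change is available, so the size of this step has to be estimated. Compound 4 is expected to show a small step upward in this assay, a number 8 percentage points higher from compound 1 to compound 4 (within the scatter), roughly within or just beyond the scatter, because compound 1 gave 0% and has no room to fall. Compound 4 is therefore estimated at 8%, in a range from 0% to 30%.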

Compound 4, a percentage reported as inhibition, at one concentration (the size of the read-out at that concentration, not a potency): 29.6%
For compound 4 the middle estimate is 21.6 percentage points below the measured one, within the range that was stated.
By their numbers in this assay, from the lowest: compound 1; then compound 2; then compound 4; then compound 3.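

In this assay, for the compounds shown here, replacing 3,5-dichlorophenyl with 2-fluorophenyl on the saturated ring carbon gives a number 29.6 percentage points higher from compound 1 to compound 4 (beyond the scatter), the first step here that can be tied to a single change. It shows that the group at this position can alter the read-out at the one concentration tested while the shared core and the acetyl group stay the same. No measured evidence is available to explain this step.

The step removes the chlorine atoms and adds a fluorine in one exchange, so the compounds shown cannot separate the effect of losing chlorine from that of gaining fluorine. As far as these compounds go, it remains open how this read-out would respond to plain phenyl, 2-chlorophenyl, or a phenyl ring carrying an amine or a carboxylic acid at this position.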